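Dodecylamide threonine series: sulfonyl in place of cinnamoyl

The source may report more compounds than this note shows. Statements on the series, on what has been measured and on what is new or still open speak of the compounds shown alone.

Among the measured compounds shown here, compound 2 `CCCCCCCCCCCCNC(=O)[C@@H](NC(=O)/C=C/c1ccccc1)[C@@H](C)O` stands level with compound 1 `CCCCCCCCCCCCNC(=O)[C@@H](NC(=O)c1ccccc1)[C@@H](C)O` on the numbers so far: in a functional assay on SW-620 cells (Homo sapiens) for cytotoxicity, read by MTT assay, with a stated time of 48 h (a higher number here means a weaker inhibitor, a lower number a stronger inhibitor), compound 2 gives 200000 nM, and compound 1 gives 200000 nM. For the measured compounds named here, the single measured step, no change at the digits printed from compound 1 to compound 2 (within the scatter), shows that swapping the aryl group on the carbonyl carbon left the read-out flat.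

Compound 3 `CCCCCCCCCCCCNC(=O)[C@@H](NS(=O)(=O)c1cccs1)[C@@H](C)O` carries a different kind of change: (thiophen-2-yl)sulfonyl in place of (2-phenylethenyl)carbonyl on an amine nitrogen. Going by the values given here, no measured step covers a sulfonyl on this nitrogen, so the flat step from the benzoyl to the cinnamoyl amide is the only guide, and it gives no reason to expect movement. In this assay compound 3 is therefore expected to sit close to the level of compound 2, a step of a 1.1-fold lower number from compound 2 to compound 3 (0.05 log units; within the scatter), with no shift beyond the scatter. The estimate for compound 3 is 180000 nM, within a range of 60000 nM to 250000 nM.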

Compound 3, half-maximal inhibitory concentration: 27900 nM
Compound 3: middle estimate off by 6.5-fold (0.81 log units), on the high side, outside the stated range (below it).
By their numbers in this assay, from the lowest: compound 3; then compounds 1 and 2 (each within the scatter of the next).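

In this assay, among the compounds shown here, the amine nitrogen of the shared core responds to what it carries: (thiophen-2-yl)sulfonyl in place of (2-phenylethenyl)carbonyl gives a 7.2-fold lower number from compound 2 to compound 3 (0.86 log units; beyond the scatter), the first step beyond the scatter. Measured against benzoyl, the same group gives a 7.2-fold lower number from compound 1 to compound 3 (0.86 log units; beyond the scatter), whereas the two carbonyl-linked groups stood level with each other. No measurement at hand bears on why the number moved.

The change replaces the carbonyl and the aromatic ring at once, so the compounds shown do not separate the contribution of the sulfonyl from that of the thiophene ring; a phenylsulfonyl group on this nitrogen would pull the two apart. Also open, going by these compounds, is whether the step holds with a shorter chain in place of the dodecyl chain.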